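Hydroxymethyl in Place of the Ester on the Shared Core

This account rests on a few compounds, and the source may have more. Where it says the series, first, only, none or still open, it means among the compounds named here.

Measured compounds:
compound 1 `COC(=O)c1cn2ccncc2n1` — this assay: > 34 nM
compound 2 `CCOC(=O)Cc1cn2cc(Br)nc(Br)c2n1` — this assay: 21 nM

In a functional assay on the whole organism for inhibition, with Cavia porcellus as the target (a lower number here means that less compound is needed, a higher number that more compound is needed for the effect), compound 1 gives > 34 nM, which is a limit of the assay and not a number. The evidence on compound 1 is therefore only this: the limit of > 34 nM in this assay, at which 1 of the 2 values shown sits. Among the measured compounds shown here, compound 2 gives 21 nM in this assay, but it differs from compound 1 in more than one place, so the two values show only that compound 2 reaches a number where compound 1 does not.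

The unmeasured compound 3 `OCc1cn2ccncc2n1` is the single-point variant of compound 1: hydroxymethyl in place of methoxycarbonyl on an aromatic carbon. Since compound 1 stands at a limit, the step cannot be measured against a number, and there is no measured step of this kind among the shown compounds. The step from compound 1 to compound 3 is expected to be a step that the limit leaves unreadable from compound 1 to compound 3, with a real chance that this assay again reports only a limit. Compound 3 is estimated at 60 nM in this assay, within a range from 15 nM to 300 nM.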

Compound 3, concentration for half-maximal effect: > 200 nM
Compound 3 gave a limit, no number; the forecaster's own chance of this, stated with the estimate: 50%; middle value at least 3.3-fold (0.52 log units) away from the limit.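

Among the compounds shown here, compound 1 and compound 3 both stand only at limits of the assay, not at numbers, so no step between them can be read. The compounds shown leave open how much, or whether, hydroxymethyl in place of methoxycarbonyl on the shared core changes the concentration needed in this assay.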